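The compounds below may be only part of what the source reports. "The series", "measured", "known", "first", "only" and "open" are said of these compounds alone.

Of the compounds shown here, three built on one shared core have been measured in an assay on CHO cells for antagonist activity at transient receptor potential cation channel subfamily V member 1 (Homo sapiens), read by FLIPR; on this read-out higher numbers stand for weaker inhibition and lower numbers for stronger inhibition. Compound 1, `CCCCCCOc1cc(C(C)(F)F)ccc1CNC(=O)C(C)c1ccc(NS(C)(=O)=O)c(F)c1`, gives 0.8 nM. Compound 2, `CC(C(=O)NCc1ccc(C(F)(F)F)cc1OC1CCCCC1)c1ccc(NS(C)(=O)=O)c(F)c1`, gives 0.7 nM, the lowest of the three numbers; its separation from compound 1 lies within the usual scatter, so no order between these two can be claimed. Compound 3, `C[C@@H](C(=O)NCc1ccc(C(F)(F)F)cc1SC1CCCCC1)c1ccc(NS(C)(=O)=O)c(F)c1`, gives 13.9 nM, a number that stands well beyond the scatter from compound 2.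

Compound 4, `CC(C(=O)NCc1ccc(C(F)(F)F)cc1C1CCCCC1)c1ccc(NS(C)(=O)=O)c(F)c1`, has not yet been measured in this assay. It differs from compound 2 in one place: cyclohexyl in place of cyclohexyloxy on an aromatic carbon. The cyclohexyl group of compound 4 sits where the cyclohexyloxy group of compound 2 sat, on an aromatic carbon ortho to a large group and meta to a trifluoromethyl group.

Among the compounds with values here, no pair of measured compounds isolates this change, so there is no directly comparable step. Within the data shown here, the only guidance is that compound 2 gives 0.7 nM while compound 3, which carries a different six-membered ring attachment on the same core, gives 13.9 nM. A modest rise in the number, possibly beyond the scatter, is expected. Compound 4 is therefore estimated to give about 3 nM, within a range from 0.8 nM to 12 nM. This estimate means an expected step of a 4.3-fold higher number from compound 2 to compound 4 (0.63 log units; beyond the scatter).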

Compound 4, inhibition constant: 0.6 nM
Compound 4: middle estimate off by 5.0-fold (0.70 log units), on the high side, outside the stated range (below it).
By their numbers in this assay, from the lowest: compounds 4, 2 and 1 (each within the scatter of the next); then compound 3.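

The step, a 1.2-fold lower number from compound 2 to compound 4 (0.07 log units; within the scatter), lies within the scatter in this assay, so compound 2 and compound 4 cannot be told apart on this read-out. At this position, on an aromatic carbon ortho to a large group and meta to a trifluoromethyl group, the cyclohexyl ring therefore need not be attached through oxygen: compound 4 gives 0.6 nM with the ring bonded directly to the aromatic carbon and without the hydrogen-bond acceptor that cyclohexyloxy carries. No measurement shown here gives a reason for this result.

The compounds shown leave open whether this holds for other groups bonded directly at the same place, such as a cyclopentyl ring, a phenyl ring or a straight hexyl chain, and how a cyclohexylamino group, with nitrogen as the link, or a morpholine ring would read there. They also leave open whether cyclohexyl and cyclohexyloxy would still match if a group such as chlorine or a nitrile stood in place of the trifluoromethyl group, since both compounds carry trifluoromethyl.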